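Halogen swap on the benzyl ring of the shared core

The source may hold more compounds than are shown below. What is called first, only, known or untested is meant among the compounds shown, and "the series" means these compounds.

Measured so far:
- compound 1 `Fc1cccc(F)c1Cc1cnc(Nc2ccc(COc3ccncc3)cc2)o1`: > 100000 nM
- compound 2 `COCc1ccc(Nc2ncc(Cc3c(F)cccc3F)o2)cc1`: 32000 nM
- compound 3 `Fc1cccc(F)c1Cc1cnc(Nc2ccc(COCc3ccco3)cc2)o1`: 31000 nM

In an ADME assay on MT2 cells (Homo sapiens) for cytotoxicity, read by MTT assay (a higher number here means that more compound is tolerated, a lower number that less compound is tolerated), compound 1 reaches only a limit of the assay, (the limit of > 100000 nM in this assay, at which 1 of the 3 values shown sits). Compound 2 gives 32000 nM and compound 3 gives 31000 nM. The two measured steps from the limit, an at least 3.1-fold lower number from compound 1 to compound 2 (0.49 log units; beyond the scatter) and an at least 3.2-fold lower number from compound 1 to compound 3 (0.50 log units; beyond the scatter), both change what sits on the oxygen on the saturated carbon. Between the two numbered compounds the step of a 1.0-fold lower number from compound 2 to compound 3 (0.01 log units; within the scatter) lies within the scatter. Compound 2 thus holds the highest of the two numbers, with compound 3 within the scatter of it; the third value shown is a limit, not a number.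

Compound 4 `COCc1ccc(Nc2ncc(Cc3c(Cl)cccc3Cl)o2)cc1` is not yet measured. It differs from compound 2 by 2,6-dichlorophenyl in place of 2,6-difluorophenyl on a saturated chain carbon bound to an aromatic carbon. Among the measured compounds shown here, none of the measured steps touches this place: all three concern the group on the oxygen on the saturated carbon, and no pair of compounds here differs at the 2,6-difluorophenyl. No step beyond the scatter is therefore expected, in either direction. The estimate for compound 4 in this assay is 25000 nM, between 10000 nM and 70000 nM, which is expected to mean a step of a 1.3-fold lower number from compound 2 to compound 4 (0.11 log units; within the scatter).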

Compound 4, half-maximal cytotoxic concentration: 8100 nM
Compound 4: the middle estimate sits 3.1-fold (0.49 log units) above what was measured; the whole stated range lies above it.
By their numbers in this assay, from the lowest: compound 4; then compounds 3 and 2 (each within the scatter of the next). At a limit, above all of these: compound 1.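

In this assay, among the compounds shown here, the 2,6-dichlorophenyl in place of 2,6-difluorophenyl on a saturated chain carbon bound to an aromatic carbon gives a 4.0-fold lower number from compound 2 to compound 4 (0.60 log units; beyond the scatter) and so shows that this place, which none of the earlier steps touched, also moves the number, in the direction of less compound tolerated. The leaving and entering groups match in heavy-atom count, in their six-membered aromatic ring of carbon only, in hydrogen-bond donors and acceptors and in net charge. The leaving group carries fluorine on that ring and the entering group carries chlorine. Nothing among the data shown bears on why this exchange changes the number.

From the compounds shown here alone, the step is read once, with methyl on the oxygen on the saturated carbon, so it remains open whether the same exchange would act alike with the pyridin-4-yl of compound 1 or the (furan-2-yl)methyl of compound 3 on that oxygen. Also open, going by these compounds, is where a plain phenyl, a 2,6-dibromophenyl or a 2,6-dimethylphenyl at this place would fall relative to compound 2 and compound 4.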